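Methyl-for-hydrogen step on the aryl ether of compound 3

The compounds below may be only part of what the source reports. "The series", "measured", "known", "first", "only" and "open" are said of these compounds alone.

Measured so far in a physicochemical assay, with a stated time of 30 min; a higher number here means a weaker inhibitor, a lower number a stronger inhibitor:
compound 1, `COc1ccc(NC(=O)C2Cc3cc(OC)c(OC)cc3C2=O)cc1`, 49.5 ug/mL
compound 2, `CCOc1ccc(NC(=O)C2Cc3cc(OC)c(OC)cc3C2=O)cc1`, 48.2 ug/mL
compound 3, `COc1ccccc1NC(=O)C1Cc2cc(OC)c(OC)cc2C1=O`, 45.8 ug/mL

Compound 4, `CCOc1ccccc1NC(=O)C1Cc2cc(OC)c(OC)cc2C1=O`, remains to be measured in this assay. It differs from compound 3 by methyl in place of hydrogen on a saturated chain carbon bound to an oxygen on an aromatic ring. The same change has been made once already, and in this assay it gave a 1.0-fold lower number from compound 1 to compound 2 (0.01 log units; within the scatter). The two cores carrying this change differ by 2-methoxyphenyl in place of 4-methoxyphenyl on an amide-type nitrogen, a difference that in this assay gave a 1.1-fold lower number from compound 1 to compound 3 (0.03 log units; within the scatter). For the measured compounds named here, all three numbers so far lie within the scatter of one another, so no order among compounds 1, 2 and 3 can be read from them. The step expected in this assay is a 1.0-fold lower number from compound 3 to compound 4 (0.01 log units; within the scatter), about as flat as the earlier one, resting on a 1.0-fold lower number from compound 1 to compound 2 (0.01 log units; within the scatter). Compound 4 is accordingly estimated at 45 ug/mL, with an expected range from 30 ug/mL to 68 ug/mL.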

Compound 4, half-maximal inhibitory concentration: 63.7 ug/mL
The estimate for compound 4 lay 1.4-fold (0.15 log units) below the measured number; the measured number falls inside the stated range.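

In this assay the methyl-for-hydrogen change, methoxy to ethoxy, gives a 1.4-fold higher number from compound 3 to compound 4 (0.14 log units; within the scatter) on the core of compound 3 and a 1.0-fold lower number from compound 1 to compound 2 (0.01 log units; within the scatter) on the core of compound 1. Both steps lie within the scatter, so on neither core can the change be told apart from repeat measurement, and these two pairs show no difference between the cores that can be read. Two pairs set no rule for the wider series, and nothing measured here speaks to the reason for either number.

Still open, from the compounds shown here alone, is whether a longer chain such as propoxy, or an amine or a carboxylic acid in place of the alkoxy group, would give a step beyond the scatter.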